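Working notes: tert-butoxy in place of cyclohexyl

The source may hold more compounds than are shown below. What is called first, only, known or untested is meant among the compounds shown, and "the series" means these compounds.

Compound 1 `CC(C)c1ccc(C(=O)N/N=C/c2ccc([N+](=O)[O-])o2)cc1`: > 200000 nM (a limit)
Compound 2 `O=C(N/N=C/c1ccc([N+](=O)[O-])o1)C1CCCCC1`: > 200000 nM (a limit)

Both measured compounds were tested in an ADME assay on LL24 cells (Homo sapiens) for inhibition, read by MTT assay, with a stated time of 24 h (on this read-out higher numbers stand for weaker inhibition and lower numbers for stronger inhibition), and neither gives a number. Among the compounds with values here, the series so far sits at the limit of > 200000 nM in this assay, at which 2 of the 2 values shown sit. In this assay compound 2 gives > 200000 nM, which is a limit of the assay and not a number.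

Compound 3 `CC(C)(C)OC(=O)N/N=C/c1ccc([N+](=O)[O-])o1` has tert-butoxy in place of cyclohexyl on a carbonyl carbon.

Within the data shown here, no step between measured compounds is available, so no measured size of change can guide this one. No change beyond the scatter is expected in this assay, in either direction, and this expectation rests on compound 2 with its limit of > 200000 nM. The expected a number no higher from compound 2 to compound 3 (the limit leaves the size open) is therefore small. Compound 3 is estimated at 200000 nM, with an expected range of 80000 nM to 400000 nM.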

Compound 3, half-maximal inhibitory concentration: > 200000 nM
Compound 3 was reported as a limit (the forecaster's own chance of this, stated with the estimate: 70%); the middle value lies on the limit itself.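

In this assay compound 2 and compound 3 both stand at a limit and not at a number, so the step from cyclohexyl to tert-butoxy on a carbonyl carbon cannot be read. The compounds shown leave open whether any group at this place gives a measurable value.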